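Extending the amine substituent: from compound 3 to compound 4

This account rests on a few compounds, and the source may have more. Where it says the series, first, only, none or still open, it means among the compounds named here.

Measured compounds:
- compound 1, `O=C(c1ccccc1)N1N=C(c2cc3ccccc3oc2=O)CC1c1ccccc1`, gives 5870 nM in a functional assay on PC-3 cells (Homo sapiens) for cytotoxicity, read by MTT assay, with a stated time of 48 h; a higher number here means a weaker inhibitor, a lower number a stronger inhibitor
- compound 2, `Cc1ccc(C(=O)N2N=C(c3cc4ccccc4oc3=O)CC2c2ccccc2)cc1`, gives 13200 nM in this assay
- compound 3, `CNCC(=O)N1N=C(c2cc3ccccc3oc2=O)CC1c1ccccc1`, gives 2300 nM in this assay

All three share the same core; they differ only in the group attached to the carbonyl carbon. Compound 3 stands lowest of the three numbers, and so is the strongest inhibitor here: its step from compound 1 is a 2.6-fold lower number from compound 1 to compound 3 (0.41 log units; beyond the scatter), and from compound 2 it is a 5.7-fold lower number from compound 2 to compound 3 (0.76 log units; beyond the scatter). Between compound 1 and compound 2 the step is a 2.2-fold higher number from compound 1 to compound 2 (0.35 log units; beyond the scatter).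

Compound 4, `CC(C)CNCC(=O)N1N=C(c2cc3ccccc3oc2=O)CC1c1ccccc1`, has not yet been measured. It differs from compound 3 by isopropyl in place of hydrogen on a saturated chain carbon bound to an amine nitrogen. For the measured compounds named here, none of the measured steps touches this position; they all concern the group on the carbonyl carbon itself. Going by the values given here, the one step that adds carbon without changing anything else, from compound 1 to compound 2, gave a modest weakening, so an enlargement here might do the same, but this is a loose comparison. A small step in either direction, or none beyond the scatter, is therefore expected in this assay.

The estimate for compound 4 is 2900 nM, with a range from 1100 nM to 7500 nM, meaning an expected step of a 1.3-fold higher number from compound 3 to compound 4 (0.10 log units; within the scatter).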

Compound 4, half-maximal inhibitory concentration: 1920 nM
Estimate against measurement, compound 4: 1.5-fold (0.18 log units) above; the measured number falls inside the stated range.
By their numbers in this assay, from the lowest: compounds 4 and 3 (each within the scatter of the next); then compound 1; then compound 2.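

In this assay, isopropyl in place of hydrogen on a saturated chain carbon bound to an amine nitrogen, which turns methylamino into isobutylamino, gives a 1.2-fold lower number from compound 3 to compound 4 (0.08 log units; within the scatter), so this position accepts the added carbons with no step beyond the scatter. The advantage of the amine side chain over the aromatic groups on the carbonyl carbon also remains with the larger group, as shown by a 6.9-fold lower number from compound 2 to compound 4 (0.84 log units; beyond the scatter) and by a 3.1-fold lower number from compound 1 to compound 4 (0.49 log units; beyond the scatter), and the earlier compounds, which carried only the small methylamino group, could not show this. No measurement is available that would explain why the larger group leaves the number within the scatter.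

Going by these compounds, whether the same holds for a much longer chain, a cyclohexyl ring or a carboxylic acid on the amine nitrogen remains open. On these data alone, the role of the amine nitrogen itself also remains open: a plain pentyl chain on the carbonyl carbon would separate the effect of that nitrogen from the effect of removing the aromatic ring.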